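Bromo for methyl on the phenoxy ring: compound 4

This account rests on a few compounds, and the source may have more. Where it says the series, first, only, none or still open, it means among the compounds named here.

Measured compounds in a functional assay on HEK293 cells for antagonist activity at thromboxane A2 receptor (Homo sapiens), read by fluorescence and calcium flux; a lower number here means a stronger inhibitor, a higher number a weaker inhibitor:
compound 1 `Cc1ccc(Oc2ccc(C#N)cc2S(=O)(=O)NC(=O)NC(C)(C)C)cc1` gives 680 nM
compound 2 `CCCCCNC(=O)NS(=O)(=O)c1cc(C#N)ccc1Oc1ccc(C)cc1` gives 630 nM
compound 3 `CC(C)NC(=O)NS(=O)(=O)c1cc(C#N)ccc1Oc1ccc(Cl)cc1` gives 8490 nM

Compound 1 stands second highest of the three numbers; compound 2 lies within scatter of it, compound 3 far above. Compound 4 `CC(C)(C)NC(=O)NS(=O)(=O)c1cc(C#N)ccc1Oc1ccc(Br)cc1` differs from compound 1 by bromo in place of methyl on an aromatic carbon. For the measured compounds named here, no measured pair isolates this change. Compound 3 carries a halogen on the same ring but differs from compound 1 in two places, so its much higher number cannot be assigned to either change alone. Going by the values given here, the single clean step, a 1.1-fold lower number from compound 1 to compound 2 (0.03 log units; within the scatter), concerns the other end of the molecule and was within scatter. The expectation is therefore uncertain, leaning toward a somewhat higher number. Compound 4 is expected near 1200 nM, between 400 nM and 4000 nM. The expected step is a 1.8-fold higher number from compound 1 to compound 4 (0.25 log units; within the scatter).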

Compound 4, half-maximal inhibitory concentration: 5310 nM
Compound 4: middle estimate off by 4.4-fold (0.65 log units), on the low side; the whole stated range lies below it.
By their numbers in this assay, from the lowest: compounds 2 and 1 (each within the scatter of the next); then compounds 4 and 3 (each within the scatter of the next).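

In this assay, for the compounds shown here, the change from 4-methylphenoxy to 4-bromophenoxy gives a 7.8-fold higher number from compound 1 to compound 4 (0.89 log units; beyond the scatter) and is the first single-place step read on this ring. Unlike the step at the other end of the molecule, it lies beyond the scatter, so this position is not indifferent to the swap. Nothing available bears on the reason for this step.

As far as these compounds go, whether other groups in this place behave like bromo remains open, for example fluoro or methoxy with the tert-butyl group kept. How much of the high number of compound 3 belongs to its chloro group also remains unresolved.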